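The compounds below may be only part of what the source reports. "The series", "measured", "known", "first", "only" and "open" are said of these compounds alone.

Compound 2 `COc1ccc(/C=C\C(=O)O)c(OCc2cn(-c3ccccc3I)nn2)c1CC=C(C)C` gives 42300 nM in a functional assay on NCI-H322 cells (Homo sapiens) for cytotoxicity, read by MTT assay, with a stated time of 24 h; a higher number here means a weaker inhibitor, a lower number a stronger inhibitor. Compound 1 `COc1ccc(/C=C\C(=O)O)c(OCc2cn(-c3ccc(NC(C)=O)cc3)nn2)c1CC=C(C)C` gives 45700 nM in this assay. Of these two numbers compound 2 holds the lower one, yet the step of a 1.1-fold lower number from compound 1 to compound 2 (0.03 log units; within the scatter) lies within the scatter, so the two compounds cannot be told apart on these data. Compound 3 `COc1ccc(/C=C\C(=O)O)c(OCc2cn(-c3cccc([N+](=O)[O-])c3)nn2)c1CC=C(C)C` arises from compound 2 by one change: 3-nitrophenyl in place of 2-iodophenyl on an aromatic nitrogen. Among the compounds with values here, the only measured step that touches the same place is a 1.1-fold lower number from compound 1 to compound 2 (0.03 log units; within the scatter), an exchange of one aromatic group for another on that aromatic nitrogen, and it produced nothing beyond the scatter. For compound 3 only a small step is therefore expected, a 1.0-fold higher number from compound 2 to compound 3 (0.02 log units; within the scatter), in no clear direction. Compound 3 is estimated at 44000 nM in this assay, with a range from 20000 nM to 95000 nM.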

Compound 3, half-maximal inhibitory concentration: 43200 nM
For compound 3 the middle estimate is 1.0-fold (0.01 log units) above the measured one; measured number inside the range.
By their numbers in this assay, from the lowest: compounds 2, 3 and 1 (each within the scatter of the next).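

The exchange of 2-iodophenyl for 3-nitrophenyl on the aromatic nitrogen gives a 1.0-fold higher number from compound 2 to compound 3 (0.01 log units; within the scatter) in this assay, and the exchange of 4-acetamidophenyl for 3-nitrophenyl gives a 1.1-fold lower number from compound 1 to compound 3 (0.02 log units; within the scatter). A third aromatic group on this nitrogen, one that brings hydrogen-bond acceptors where 2-iodophenyl has none, therefore still produces no readable change, so compound 1, compound 2 and compound 3 cannot be told apart in this assay. No measured evidence is available to explain this flat result.

Going by these compounds, all three compounds carry a substituted phenyl ring on this nitrogen, so it remains open whether an open alkyl chain, a benzyl group or a saturated ring bearing an amine would shift the number. Changes elsewhere on the shared core also remain open.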